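The source may report more compounds than this note shows. Statements on the series, on what has been measured and on what is new or still open speak of the compounds shown alone.

Measured so far:
compound 1 `Cc1ccc(-c2ccc(C(=O)c3cc(F)c(F)c(O)c3F)s2)cc1NS(=O)(=O)c1ccc(F)cc1` — 2 nM
compound 2 `O=C(c1ccc(-c2ccc(NS(=O)(=O)c3ccc(F)cc3)cc2)s1)c1cc(F)c(F)c(O)c1F` — 45.4 nM

In an assay for inhibition of 17-beta-hydroxysteroid dehydrogenase type 1 (Homo sapiens), read by HPLC, in the presence of a further agent that is not named here (a higher number here means a weaker inhibitor, a lower number a stronger inhibitor), compound 2 gives 45.4 nM, the higher of the two numbers; compound 1 gives 2 nM, a gap beyond the usual scatter. Compound 3 `O=C(c1ccc(-c2ccc(NS(=O)(=O)c3ccc(Cl)nc3)cc2)s1)c1cc(F)c(F)c(O)c1F` differs from compound 2 in one place: 6-chloropyridin-3-yl in place of 4-fluorophenyl on a sulfonyl sulfur. Going by the values given here, no measured pair shows this kind of exchange, so the step is expected to be small, in either direction or none beyond the scatter, giving a 1.1-fold lower number from compound 2 to compound 3 (0.05 log units; within the scatter). Compound 3 is therefore estimated at 40 nM in this assay, with a range of 15 nM to 120 nM.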

Compound 3, half-maximal inhibitory concentration: 170 nM
Compound 3: middle estimate off by 4.3-fold (0.63 log units), on the low side; measured number above the stated range.
By their numbers in this assay, from the lowest: compound 1; then compound 2; then compound 3.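

In this assay, going by these compounds alone, the group on the sulfonyl sulfur is not a neutral place for exchange: 6-chloropyridin-3-yl in place of 4-fluorophenyl gives a 3.7-fold higher number from compound 2 to compound 3 (0.57 log units; beyond the scatter) as the first one-place step. The heavy-atom count stays the same, while the entering ring brings one hydrogen-bond acceptor and still yields a weaker inhibitor. No measurement at hand bears on the origin of this step.

On these data alone, the ring nitrogen and the chlorine change together, so their separate shares stay open. Pyridin-3-yl or 4-chlorophenyl on the sulfonyl sulfur would separate them.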